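The source may hold more compounds than are shown below. What is called first, only, known or untested is meant among the compounds shown, and "the series" means these compounds.

Working notes on the series.

Compound 1 `COC(=O)c1ccc(-c2cnc(C(=O)CCCCCCc3ccccc3)o2)cc1` gives, in an assay (Rattus norvegicus) for inhibition of Fatty-acid amide hydrolase 1 (Homo sapiens) (on this read-out lower numbers stand for stronger inhibition and higher numbers for weaker inhibition), a value of 40 nM. Compound 2 `COc1ccc(-c2cnc(C(=O)CCCCCCc3ccccc3)o2)cc1` gives in this assay a value of 100 nM. Among the compounds with values here, the one step measured so far, a 2.5-fold higher number from compound 1 to compound 2 (0.40 log units; beyond the scatter), changes only the group on the phenyl ring. Within the data shown here, on the two numbers available, compound 2 stands highest, with compound 1 as its only neighbour, a modest way below it.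

Compound 3 `NC(=O)c1cccc(-c2cnc(C(=O)CCCCCCc3ccccc3)o2)n1` is yet to be measured. It differs from compound 2 as follows: 6-carbamoylpyridin-2-yl in place of 4-methoxyphenyl on an aromatic carbon. Among the measured compounds shown here, no measured step covers this change directly; the only step available, a 2.5-fold higher number from compound 1 to compound 2 (0.40 log units; beyond the scatter), concerns a swap of the group on the phenyl ring rather than replacement of the whole ring, so it bears on the present step only loosely. That step was modest, and the present change is larger in scope but in the same part of the molecule. A step of similar or somewhat greater size in this assay, in either direction, is therefore considered possible, with no firm basis to prefer one direction.

Compound 3 is expected to give about 60 nM in this assay, within a range of 12 nM to 300 nM; this corresponds to an expected step of a 1.7-fold lower number from compound 2 to compound 3 (0.22 log units; within the scatter).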

Compound 3, inhibition constant: 1 nM
Estimate against measurement, compound 3: 60-fold (1.78 log units) above; measured number below the stated range.
By their numbers in this assay, from the lowest: compound 3; then compound 1; then compound 2.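

In this assay, 6-carbamoylpyridin-2-yl in place of 4-methoxyphenyl, on the aromatic carbon next to the ring oxygen, gives a 100-fold lower number from compound 2 to compound 3 (2.00 log units; beyond the scatter). This is far larger than the only earlier step, a 2.5-fold higher number from compound 1 to compound 2 (0.40 log units; beyond the scatter), so a position that had shown a modest response to a change of group on the phenyl ring can move this read-out strongly when the whole ring is replaced. The entering group differs from the leaving one at once in its ring hetero atom, its carbamoyl group and its hydrogen-bond donor, and nothing on hand assigns the step to any one of these.

The compounds shown do not separate the ring nitrogen from the carbamoyl group: it remains open whether a plain pyridin-2-yl or a carbamoylphenyl would keep any of the step. Also open, as far as these compounds go, is whether a carboxylic acid or a methyl ester in place of the carbamoyl group on the pyridine ring would hold the number of compound 3, and whether a shorter chain on the shared core would alter the step.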